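Amine-bearing side chains on the shared core

A few compounds are considered here, and "the series" means these few. Any claim that something is new, unique, unknown or untested is made for them only; others in the source may bear on it.

Measured so far:
compound 1 `CN(C)CCn1nc(Cc2ccc(Cl)cc2)c2ccccc2c1=O`, 158 nM
compound 2 `CN1CCCCC(n2nc(Cc3ccc(Cl)cc3)c3ccccc3c2=O)C1`, 158 nM

In an assay for binding affinity to Alpha-1A adrenergic receptor (Homo sapiens) (on this read-out higher numbers stand for weaker inhibition and lower numbers for stronger inhibition), compound 1 gives 158 nM. Compound 2 `CN1CCCCC(n2nc(Cc3ccc(Cl)cc3)c3ccccc3c2=O)C1` stands level with compound 1, the step of no change at the digits printed from compound 1 to compound 2 (within the scatter) lying within the scatter. Compound 3 `CN1CCCC1CCn1nc(Cc2ccc(Cl)cc2)c2ccccc2c1=O` is not yet measured; it carries 2-(1-methylpyrrolidin-2-yl)ethyl in place of 1-methylazepan-3-yl on an aromatic nitrogen. Within the data shown here, the one step that bears on this, no change at the digits printed from compound 1 to compound 2 (within the scatter), swapped one basic side chain for another without change in this assay. The expectation is therefore a step of a 1.0-fold higher number from compound 2 to compound 3 (0.01 log units; within the scatter), that is, none beyond the scatter. Compound 3 is estimated at 160 nM, range 60 nM to 450 nM.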

Compound 3, inhibition constant: 316 nM
For compound 3 the middle estimate is 2.0-fold (0.30 log units) below the measured one; the measured number falls inside the stated range.
By their numbers in this assay, from the lowest: compounds 1, 2 and 3 (each within the scatter of the next).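

In this assay, 2-(1-methylpyrrolidin-2-yl)ethyl on the aromatic nitrogen stays within the scatter of both earlier side chains: against 1-methylazepan-3-yl the result is (a 2.0-fold higher number from compound 2 to compound 3 (0.30 log units; within the scatter)), and with 1-methylpyrrolidin-2-yl in place of dimethylamino on the chain it is (a 2.0-fold higher number from compound 1 to compound 3 (0.30 log units; within the scatter)). Three differently arranged amine side chains, including a five-membered and a seven-membered ring, therefore show no step beyond the scatter at this position. No data here offer an explanation for these numbers.

Still open, as far as these compounds go, is whether this level holds with a side chain lacking the amine, such as a simple ethyl group or a carboxylic acid. From the compounds shown here alone, a longer chain to the amine also remains open.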